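The source may hold more compounds than are shown below. What is called first, only, known or untested is meant among the compounds shown, and "the series" means these compounds.

- Compound 1 `O=C(O)c1ccc(CN2CCC[C@H](O[C@H](CO)c3cc(Cl)cc(Cl)c3)[C@@H]2c2ccccc2)c([N+](=O)[O-])c1`: 112000 nM
- Compound 2 `Nc1cc(C(=O)O)ccc1CN1CCC[C@H](O[C@H](CO)c2cc(Cl)cc(Cl)c2)[C@@H]1c1ccccc1`: 137000 nM

For the measured compounds named here, in a physicochemical assay for solubility, in simulated intestinal fluid (a lower number here means a less soluble compound, a higher number a more soluble compound), compound 2 gives 137000 nM, and compound 1, the only other measured compound, lies within the scatter of it. Compound 3 `Cc1cc(C(=O)O)ccc1CN1CCC[C@H](O[C@H](CO)c2cc(Cl)cc(Cl)c2)[C@@H]1c1ccccc1` carries methyl in place of amino on an aromatic carbon, ortho to a large group and meta to a carboxy group: methyl in place of amino on an aromatic carbon. Going by the values given here, the one measured step that bears on this, amino in place of nitro, is a 1.2-fold higher number from compound 1 to compound 2 (0.09 log units; within the scatter). That single step is thin evidence, and it gives no reason to expect a change beyond the scatter in this assay. The expected step is a 1.2-fold lower number from compound 2 to compound 3 (0.10 log units; within the scatter). For compound 3 the estimate is 110000 nM, with an expected range of 50000 nM to 220000 nM.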

Compound 3, solubility: 36000 nM
For compound 3 the middle estimate is 3.1-fold (0.49 log units) above the measured one, outside the stated range (below it).
By their numbers in this assay, from the lowest: compound 3; then compounds 1 and 2 (each within the scatter of the next).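

In this assay the group on this aromatic carbon, ortho to a large group and meta to a carboxy group, can move the number beyond the scatter, which the amino and nitro compounds alone did not show. Methyl in place of amino gives a 3.8-fold lower number from compound 2 to compound 3 (0.58 log units; beyond the scatter) and methyl in place of nitro gives a 3.1-fold lower number from compound 1 to compound 3 (0.49 log units; beyond the scatter) on the same carbon. No evidence here says why methyl stands apart.

Still open, from the compounds shown here alone, is whether a hydroxyl, a methoxy or an ethyl group on this carbon would read like methyl or like amino and nitro.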